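The compounds below may be only part of what the source reports. "The series", "measured", "known", "first", "only" and "open" are said of these compounds alone.

Compound 1 `CC(=O)Oc1ccc2cc(-c3cccs3)c(=O)oc2c1OC(C)=O` carries a thiophen-2-yl group on its core and, in an assay on CHO cells for displacement of a labelled ligand from adenosine receptor A1 (Homo sapiens) (a higher number here means a weaker inhibitor, a lower number a stronger inhibitor), compound 1 gives > 100000 nM, which is a limit of the measurement rather than a number. Compound 2 `CC(=O)Oc1ccc2cc(-c3ccsc3)c(=O)oc2c1OC(C)=O` carries thiophen-3-yl in place of thiophen-2-yl on an aromatic carbon, and in this assay compound 2 gives > 100000 nM, again a limit. The step that the two limits leave unreadable from compound 1 to compound 2 therefore cannot be read in size or direction. Compound 3 `CC(=O)Oc1cccc2cc(-c3cc(Br)cs3)c(=O)oc12` has a single acetoxy group on its core and a bromine on the thiophene, and in this assay compound 3 gives > 100000 nM, once more a limit. Compound 3 thus stands at the limit of > 100000 nM in this assay, at which 3 of the 3 values shown sit, so no shown value separates it from the other two compounds.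

Compound 4 `CC(=O)Oc1ccc2cc(-c3cc(Br)cs3)c(=O)oc2c1OC(C)=O` differs from compound 3 by acetoxy in place of hydrogen on an aromatic carbon. No measured step speaks to this change, and the one shown step is itself unreadable. With every value resting at the same limit, nothing points to a gain in potency. The step that the limit leaves unreadable from compound 3 to compound 4 is therefore expected to show no shift beyond the scatter. Compound 4 is expected to give about 150000 nM in this assay, with an estimated range from 50000 nM to 500000 nM, most probably reported only as a limit.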

Compound 4, inhibition constant: > 100000 nM
Compound 4: only a limit was reported; the forecaster's own chance of this, stated with the estimate: 85%; the middle value lies beyond the limit too.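

In this assay compound 4 gives > 100000 nM, which is a limit and not a number. Its steps from compound 1, compound 2 and compound 3 therefore cannot be read in size or direction. The compounds shown leave open whether any change to the thiophene or the acetoxy groups on the shared core alters the value in this assay.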